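Five-membered aryl groups on the shared core: thiazole entry

The source may report more compounds than this note shows. Statements on the series, on what has been measured and on what is new or still open speak of the compounds shown alone.

Measured compounds:
- compound 1, `c1csc(-c2ccccc2OCC2=NCCN2)c1`: 15.9 nM
- compound 2, `c1c[nH]c(-c2ccccc2OCC2=NCCN2)c1`: 6.31 nM
- compound 3, `c1ccc(-c2ccsc2)c(OCC2=NCCN2)c1`: 12.6 nM

All three were read in a functional assay for activation of Alpha-1D adrenergic receptor (Homo sapiens), read by calcium flux; on this read-out higher numbers stand for an effect only at larger amounts of compound and lower numbers for an effect already at smaller amounts. Compound 3 stands second highest of the three numbers; its nearest neighbour is compound 1, and the step of a 1.3-fold lower number from compound 1 to compound 3 (0.10 log units; within the scatter) lies within the scatter. The step of a 2.0-fold higher number from compound 2 to compound 3 (0.30 log units; within the scatter) also lies within the scatter, so compounds 2 and 3 cannot be ordered against each other. For the measured compounds named here, the only step beyond the scatter is a 2.5-fold lower number from compound 1 to compound 2 (0.40 log units; beyond the scatter), a modest one.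

The unmeasured compound 4, `Cc1cnsc1-c1ccccc1OCC1=NCCN1`, differs from compound 3 in one place: 4-methyl-1,2-thiazol-5-yl in place of thiophen-3-yl on an aromatic carbon. Going by the values given here, no measured step swaps a five-membered ring with one hetero atom for one with two, nor adds a methyl group to such a ring, so nothing bears on it directly. The steps that exchange one five-membered aryl group for another, a 1.3-fold lower number from compound 1 to compound 3 (0.10 log units; within the scatter) and a 2.0-fold higher number from compound 2 to compound 3 (0.30 log units; within the scatter), both stay within the scatter, and even a 2.5-fold lower number from compound 1 to compound 2 (0.40 log units; beyond the scatter) is only modest. A step of a 1.1-fold lower number from compound 3 to compound 4 (0.02 log units; within the scatter) is therefore expected, within the scatter. For compound 4 the estimate is 12 nM, with a range from 4 nM to 40 nM.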

Compound 4, half-maximal effective concentration: < 100000 nM
Compound 4: only a limit was reported (the forecaster's own chance of this, stated with the estimate: 5%); the middle value lies beyond the limit too.
By their numbers in this assay, from the lowest: compounds 2, 3 and 1 (each within the scatter of the next, the first and the last beyond it).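

In this assay compound 4 gives < 100000 nM, which is a limit and not a number. For the compounds shown here, no step from compound 1, compound 2 or compound 3 to compound 4 can therefore be read. The compounds shown leave open whether 4-methyl-1,2-thiazol-5-yl shifts the number at all.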